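Shortening the Chain of Compound 2 to an Acetyl Group

A few compounds are considered here, and "the series" means these few. Any claim that something is new, unique, unknown or untested is made for them only; others in the source may bear on it.

Of the compounds shown here, two have so far been measured in a functional assay on NCI-H441 cells (Homo sapiens) for antiproliferative activity, with a stated time of 24 h (on this read-out lower numbers stand for stronger inhibition and higher numbers for weaker inhibition), on this series. Compound 1 (`O=C1/C(=C/c2ccccc2Br)CNC/C1=C\c1ccccc1Br`) gives 6000 nM there, while compound 2 (`O=C(O)CCCC(=O)N1C/C(=C\c2ccccc2F)C(=O)/C(=C/c2ccccc2F)C1`) gives 60000 nM and so holds the higher of the two numbers, with a gap beyond the usual scatter. Compound 2 is therefore the weaker inhibitor of the pair. The two differ in more than one place, so the gap cannot be assigned to any single change.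

Compound 3 (`CC(=O)N1C/C(=C\c2ccccc2F)C(=O)/C(=C/c2ccccc2F)C1`) has not yet been measured. It departs from compound 2 by one change, (hydrogen in place of 2-carboxyethyl on a saturated chain carbon bound to a carbonyl carbon), which is hydrogen in place of 2-carboxyethyl on a saturated chain carbon bound to a carbonyl carbon. The (3-carboxypropyl)carbonyl thus becomes acetyl.

For the measured compounds named here, no measured pair isolates this change, so the expectation is loose. Going by the values given here, it leans on compound 1 at 6000 nM as the only measured compound without the 3-carboxypropyl chain. The expected step in this assay is a 6.0-fold lower number from compound 2 to compound 3 (0.78 log units; beyond the scatter) toward stronger inhibition. For compound 3 the estimated value is 10000 nM, with 2500 nM to 40000 nM as the expected range.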

Compound 3, half-maximal inhibitory concentration: 54000 nM
Estimate against measurement, compound 3: 5.4-fold (0.73 log units) below, outside the stated range (above it).
By their numbers in this assay, from the lowest: compound 1; then compounds 3 and 2 (each within the scatter of the next).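

In this assay, the change from the (3-carboxypropyl)carbonyl to acetyl gives a 1.1-fold lower number from compound 2 to compound 3 (0.05 log units; within the scatter) and so does not separate the two groups on this read-out. For the compounds shown here, this is the first pair to isolate this place, on a saturated chain carbon bound to a carbonyl carbon, and it shows that the 2-carboxyethyl, with the carboxylic acid it carries, can give way to hydrogen without a shift beyond the scatter. No measurement offered here explains why the number holds at this place.

The compounds shown leave open whether the flat result would hold for other groups at this place, such as an amine, a hydroxyl or a longer chain, since only the 2-carboxyethyl and hydrogen have been compared there. Going by these compounds alone, they also hold no pair that differs in one place to link compound 1 with compound 3, so the bromine of compound 1, the fluorine of compound 3 and the acetyl of compound 3 cannot be weighed separately.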